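This account rests on a few compounds, and the source may have more. Where it says the series, first, only, none or still open, it means among the compounds named here.

Measured compounds: compound 1 `CCC1=C(O)c2c(oc(-c3ccc(O)cc3)cc2=O)C(CC)(CC)C1=O` with 20.6 uM; compound 2 `CCC1=C(O)c2c(oc(-c3cc(OC)c(OC)c(OC)c3)cc2=O)C(CC)(CC)C1=O` with 5.6 uM.

In a functional assay on KBVIN cells (Homo sapiens) for antiproliferative activity, read by sulforhodamine B assay, with a stated time of 3 days (on this read-out higher numbers stand for an effect only at larger amounts of compound and lower numbers for an effect already at smaller amounts), compound 1 stands at the higher of the two numbers recorded, and compound 2 at the lower one; the gap between these two values lies beyond the usual scatter, which is all that pair of values shows. Compound 3 `CCC1=C(O)c2c(oc(-c3ccc(O)c(O)c3)cc2=O)C(CC)(CC)C1=O` has not yet been measured. It differs from compound 1 in a single place: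

hydroxy in place of hydrogen on an aromatic carbon

For the measured compounds named here, no pair of measured compounds that differ in only one place is available, so this change has no measured precedent here, and the expectation rests on compound 1 alone. The step from compound 1 expected in this assay is a 1.4-fold lower number from compound 1 to compound 3 (0.14 log units; within the scatter), a small lowering that may well stay within the scatter. Compound 3 is therefore estimated at 15 uM, with a range from 5 uM to 40 uM.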

Compound 3, concentration for half-maximal effect: 5.41 uM
Compound 3: the middle estimate sits 2.8-fold (0.44 log units) above what was measured; low and high end bracket the measured number.
By their numbers in this assay, from the lowest: compounds 3 and 2 (each within the scatter of the next); then compound 1.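

Going from 4-hydroxyphenyl to 3,4-dihydroxyphenyl provides the first step between measured compounds that differ in one place: in this assay, hydroxy on the aromatic carbon ortho to a hydroxy group gives a 3.8-fold lower number from compound 1 to compound 3 (0.58 log units; beyond the scatter). This step lies beyond the usual scatter, so on the ring of compound 1 this position responds to a single added hydroxy, with the effect appearing at smaller amounts of compound. No measurement at hand bears on the reason for this step.

The compounds shown leave open whether the lowering is tied to hydroxy itself or would also follow from an amine or a fluorine atom on the same carbon. They also leave open whether the step would carry over if a longer chain replaced the ethyl groups on the core.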